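Dropping One Fluoro: Expected Cytotoxicity of Compound 4

This account rests on a few compounds, and the source may have more. Where it says the series, first, only, none or still open, it means among the compounds named here.

Compound 1 `COc1cc(-c2nnc3n2NC(c2ccco2)C(C(=O)c2ccc(F)c(F)c2)S3)cc(OC)c1OC` — 52400 nM
Compound 2 `COc1cc(-c2nnc3n2NC(c2cccs2)C(C(=O)c2ccc(F)cc2)S3)cc(OC)c1OC` — 54200 nM
Compound 3 `COc1cccc(C(=O)C2Sc3nnc(-c4cc(OC)c(OC)c(OC)c4)n3NC2c2ccco2)c1` — a limit, > 100000 nM

Of the compounds shown here, three sharing one core have been tested in a functional assay on HepG2 cells (Homo sapiens) for cytotoxicity, read by MTT assay, with a stated time of 48 h; a higher number here means a weaker inhibitor, a lower number a stronger inhibitor. Compound 1 gives 52400 nM, the lowest of the two numbers recorded. Compound 2, which carries a thiophene and a 4-fluorophenyl on the carbonyl carbon, gives 54200 nM, a value that sits within the scatter of that of compound 1. For compound 3 the assay reports only a limit, > 100000 nM.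

Among the compounds with values here, the one measured step in this assay is an at least 1.9-fold higher number from compound 1 to compound 3 (0.28 log units; that floor lies within the scatter), a change of the aryl group on the carbonyl carbon whose floor lies within the scatter (the limit of > 100000 nM in this assay, at which 1 of the 3 values shown sits).

Compound 4 `COc1cc(-c2nnc3n2NC(c2ccco2)C(C(=O)c2ccc(F)cc2)S3)cc(OC)c1OC` is not yet measured. It differs from compound 1 in a single place: hydrogen in place of fluoro on an aromatic carbon. Within the data shown here, no measured step removes a fluoro from this ring, so the step from compound 1 to compound 3 does not bear directly on it, and the pair of compound 1 and compound 2 differs in two places and offers only its two values, which lie within the scatter of each other. A step of no more than the scatter is therefore expected, in either direction.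

Compound 4 is expected to give 60000 nM in this assay, within 30000 nM to 120000 nM, an expected step of a 1.1-fold higher number from compound 1 to compound 4 (0.06 log units; within the scatter).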

Compound 4, half-maximal inhibitory concentration: > 100000 nM
Compound 4: a limit, no number (the forecaster's own chance of this, stated with the estimate: 25%); at least 1.6-fold (0.22 log units) between middle value and limit.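

In this assay, within the data shown here, compound 4 returns only a limit (> 100000 nM), which gives the first reading of this fluoro position on its own, on an aromatic carbon ortho to a fluoro group. Hydrogen in place of that fluoro gives an at least 1.9-fold higher number from compound 1 to compound 4 (0.28 log units; that floor lies within the scatter) and so does not settle the size of the change, since the step is only a floor that does not pass the scatter, and the data show neither a real loss nor its absence. Furan-2-yl in place of thiophen-2-yl likewise gives only a floor within the scatter, an at least 1.8-fold higher number from compound 2 to compound 4 (0.26 log units; that floor lies within the scatter), and the step involving compound 3 and compound 4 cannot be read, since the assay gives no number for either: the limit of > 100000 nM in this assay, at which 2 of the 4 values shown sit.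

On these data alone, what stays open is how far compound 4 truly lies from compound 1, and whether the 3-fluoro on this ring matters at all in this assay. Nor do the compounds shown tell how a chloro, a hydroxyl or an amine on this same aromatic carbon would read against the fluoro of compound 1.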